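The compounds below may be only part of what the source reports. "The series", "measured", "known", "first", "only" and "open" are said of these compounds alone.

Working notes on the series. In an assay on isolated protein for inhibition of Amine oxidase [flavin-containing] A (Homo sapiens), read by fluorescence (on this read-out lower numbers stand for stronger inhibition and higher numbers for weaker inhibition), compound 1 `O=C(/C=C/c1ccoc1)c1cc(O)c(O)c([N+](=O)[O-])c1` gives 52900 nM and compound 2 `CC(=O)N1N=C(c2cc(O)c(O)c([N+](=O)[O-])c2)CC1c1ccco1` gives 98000 nM. The two numbers lie within the scatter of each other, so compound 2 cannot be set apart from compound 1 on this assay; both are weak. Among the measured compounds shown here, no step between measured compounds is available here. Compound 3 `CC(=O)N1N=C(c2cc(O)c(O)c([N+](=O)[O-])c2)CC1c1cccc(C#N)c1` differs from compound 2 by 3-cyanophenyl in place of furan-2-yl on a saturated ring carbon. Nothing in the measured pair speaks to this exchange, so the step from compound 2 to compound 3 is expected to be small, either direction or none beyond the scatter, as a 1.4-fold lower number from compound 2 to compound 3 (0.15 log units; within the scatter). On that basis compound 3 is estimated at 70000 nM in this assay, with a range from 15000 nM to 300000 nM.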

Compound 3, half-maximal inhibitory concentration: 70600 nM
Beside the measured number, compound 3's estimate is 1.0-fold (0.00 log units) below it; the measured number falls inside the stated range.
By their numbers in this assay, from the lowest: compounds 1, 3 and 2 (each within the scatter of the next).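

In this assay, 3-cyanophenyl in place of furan-2-yl on this saturated ring carbon gives a 1.4-fold lower number from compound 2 to compound 3 (0.14 log units; within the scatter). This position therefore accepts a six-membered aromatic ring of carbon only, bearing a nitrile, in place of a five-membered aromatic ring with a hetero atom, although the entering group has more heavy atoms, and the number stays within the scatter. Nothing at hand accounts for this lack of separation between the two groups.

Among the compounds shown here, the single exchange leaves open what the ring and the nitrile each contribute, which plain phenyl or a carboxylic acid in place of the nitrile would help to separate. On these data alone, it also remains open whether any group on this carbon, such as an aminomethyl-bearing phenyl or a longer alkyl chain, would move the number beyond the scatter.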